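Sulfanyl-chain variations on the shared core: cytotoxicity notes

The source may report more compounds than this note shows. Statements on the series, on what has been measured and on what is new or still open speak of the compounds shown alone.

Compound 1 `Cc1ccc(C(=O)CSc2nnc(C)n2N2C(=O)c3ccccc3C2=O)cc1` — in a functional assay on A549 cells (Homo sapiens) for cytotoxicity, read by MTT assay, with a stated time of 48 h (a lower number here means a stronger inhibitor, a higher number a weaker inhibitor), compound 1 gives > 200000 nM, which is a limit of the assay.
Compound 2 `Cc1nnc(SCc2ccccc2Cl)n1N1C(=O)c2ccccc2C1=O` — in this assay compound 2 gives > 200000 nM, again a limit.
Compound 3 `C=CCSc1nnc(CC)n1N1C(=O)c2ccccc2C1=O` — in this assay compound 3 gives > 200000 nM, likewise a limit.

Within the data shown here, the only step between measured compounds that differ in one place is a step that the two limits leave unreadable from compound 1 to compound 2; both ends sit at the limit, so its size cannot be read. Compound 3 therefore stands exactly where the whole set stands: the limit of > 200000 nM in this assay, at which 3 of the 3 values shown sit. Among the measured compounds shown here, no value shown is a number, so no compound can be ranked against another.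

Compound 4 `CCOC(=O)CSc1nnc(CC)n1N1C(=O)c2ccccc2C1=O` differs from compound 3 in one place: ethoxycarbonyl in place of vinyl on a saturated chain carbon bound to a sulfur. For the measured compounds named here, no measured step bears on this change, since the one recorded step is unreadable. The expectation rests only on the three limits shown. Compound 4 is expected to remain at the limit, with an estimated 300000 nM, the range running from 150000 nM to 1000000 nM. The expected step that the limit leaves unreadable from compound 3 to compound 4 is none beyond the scatter, and most likely the assay will again report only a limit.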

Compound 4, half-maximal inhibitory concentration: > 200000 nM
Compound 4 gave a limit, no number; the forecaster's own chance of this, stated with the estimate: 90%; the middle value is on the limit's open side.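

In this assay compound 4 gives > 200000 nM, a limit of the assay and not a number. No new step can be read between compound 3 and compound 4. The compounds shown leave open whether any sulfanyl-chain variation on the shared core gives a readable number, with the whole set at one place: the limit of > 200000 nM in this assay, at which 4 of the 4 values shown sit.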